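The compounds below may be only part of what the source reports. "The series", "measured", "known", "first", "only" and "open" are said of these compounds alone.

Working notes on the series. Two compounds have numbers in an ADME assay on RAW264.7 cells (Mus musculus) for cytotoxicity, read by MTT assay, with a stated time of 24 h; on this read-out lower numbers stand for higher toxicity in this test and higher numbers for lower toxicity in this test. Compound 1 `O=c1oc2ccc(Cl)cc2c(=O)n1-c1ccc(I)cc1F` gives 6900 nM in this assay. Compound 2 `O=C(Nc1ccc(Cl)cc1F)c1cc(F)ccc1O` gives 7700 nM in this assay. Among the measured compounds shown here, compound 1 stands at one of two numbers that lie within the scatter of each other, with compound 2 as its only neighbour, so the two measured values cannot be told apart and no ordering between them is claimed.

Compound 3 `O=c1oc2ccc(I)cc2c(=O)n1-c1ccc(I)cc1F` has not yet been measured in this assay. Against compound 1 its structure shows (iodo in place of chloro on an aromatic carbon). For the measured compounds named here, no pair of measured compounds differs in one place, so no measured step gives a scale for this change; the expectation rests on the two values alone, both of which sit in the same region of this assay.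

The step from compound 1 to compound 3 is expected to be a 1.1-fold lower number from compound 1 to compound 3 (0.03 log units; within the scatter), with no direction claimed beyond the scatter. Compound 3 is therefore estimated at 6500 nM in this assay, within a range of 3000 nM to 14000 nM.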

Compound 3, half-maximal cytotoxic concentration: 7600 nM
Beside the measured number, compound 3's estimate is 1.2-fold (0.07 log units) below it; low and high end bracket the measured number.
By their numbers in this assay, from the lowest: compounds 1, 3 and 2 (each within the scatter of the next).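

In this assay, among the compounds shown here, iodo in place of chloro on an aromatic carbon of the shared core gives a 1.1-fold higher number from compound 1 to compound 3 (0.04 log units; within the scatter) and is the first step that differs in one place. This position, on a six-membered aromatic ring of carbon only that is part of a fused or bridged system of two rings, therefore carries chloro or iodo with values that cannot be told apart, which the unrelated pair of earlier compounds could not show. No measurement is available that would account for this outcome.

On these data alone, whether an amine, a carboxylic acid or a methoxy group at this position would stay in the same region of this assay remains open, as compound 1 and compound 3 carry only chloro and iodo there. For the compounds shown here, also open is whether iodo in place of chloro gives a similar step on any other core, as this single pair gives the only reading of that change so far.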